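A few compounds are considered here, and "the series" means these few. Any claim that something is new, unique, unknown or untested is made for them only; others in the source may bear on it.

Of the compounds shown here, three that share one core have been tested in a functional assay on MCF7 cells (Homo sapiens) for antiproliferative activity, read by MTT assay; on this read-out higher numbers stand for weaker inhibition and lower numbers for stronger inhibition. Compound 1 `CCCC/C=C\CCCCCCCCCc1cc(=O)c2c(O)cc(OCOC)cc2o1` carries the oct-3-en-1-yl chain on a core without methyl substitution; in this assay compound 1 gives > 67200 nM, which is a limit of the assay and not a number. Compound 2 `CCCC/C=C\CCCCCCCCCc1cc(=O)c2c(O)c(C)c(OCOC)c(C)c2o1` has the same chain on a methyl-substituted core, and in this assay compound 2 gives > 67200 nM, again a limit. Compound 3 `CCCCC/C=C\C/C=C\CCCCCCCc1cc(=O)c2c(O)c(C)c(OCOC)cc2o1` combines a methyl-substituted core with the longer deca-1,4-dien-1-yl chain; in this assay compound 3 gives > 67200 nM, also a limit. Compound 3 thus stands with the other two at the limit of > 67200 nM in this assay, at which 3 of the 3 values shown sit, and none of the three has a measured number.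

Compound 4 `CCCC/C=C\CCCCCCCCCc1cc(=O)c2c(O)c(C)c(OCOC)cc2o1` differs from compound 3 in one place: oct-3-en-1-yl in place of deca-1,4-dien-1-yl on a saturated chain carbon, seven bonds along the chain from an aromatic carbon. Going by the values given here, the chain of compound 4 is the one found in compound 1 and compound 2, both of which sit at the limit. Among the compounds with values here, no step between measured compounds exists here, so the expected step is a step that the limit leaves unreadable from compound 3 to compound 4, nothing beyond the scatter. Compound 4 is therefore expected to give 100000 nM, within 67200 nM to 300000 nM, most likely again as a limit, because compound 1 with the same oct-3-en-1-yl chain also sits at the limit of > 67200 nM in this assay, at which 3 of the 3 values shown sit.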

Compound 4, half-maximal inhibitory concentration: > 67200 nM
Compound 4: a limit, no number; the forecaster's own chance of this, stated with the estimate: 85%; the middle value is on the limit's open side.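

Compound 4 sits at a limit, as do compound 1, compound 2 and compound 3, so no step from any of them to compound 4 can be read: the limit of > 67200 nM in this assay, at which 4 of the 4 values shown sit.

As far as these compounds go, whether the methyl groups on the core or the choice of chain change the activity at all stays open, as none of the four compounds has a measured number.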